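Nitrobenzoate esters of a shared core on PC-3 cells

The source may report more compounds than this note shows. Statements on the series, on what has been measured and on what is new or still open speak of the compounds shown alone.

Measured so far:
compound 1, `CC1=CC[C@H](C(C)C)c2cc(C)c(OC(=O)c3ccc([N+](=O)[O-])cc3)cc21`: 36.7%
compound 2, `Cc1cc2c(C(C)C)ccc(C)c2cc1OC(=O)c1ccc([N+](=O)[O-])cc1`: 100%
compound 3, `COc1ccc(C(=O)Oc2cc3c(C)ccc(C(C)C)c3cc2C)cc1`: 10.4%

All three numbers come from a functional assay on PC-3 cells (Homo sapiens) for antiproliferative activity, read by sulforhodamine B assay, with a stated time of 48 h, tested at 50 uM; on this read-out lower numbers stand for less inhibition and higher numbers for more inhibition at the one concentration tested (going by the name of the read-out). Compound 1 stands second highest of the three; compound 3 lies lower and compound 2 higher, both gaps beyond the scatter. Among the compounds with values here, the only step between compounds that differ in one place is a number 89.6 percentage points lower from compound 2 to compound 3 (beyond the scatter); it exchanges the nitro group for a methoxy group and so does not bear on the present change. Compound 4, `CC1=CC[C@H](C(C)C)c2cc(C)c(OC(=O)c3cccc([N+](=O)[O-])c3)cc21`, differs from compound 1 by 3-nitrophenyl in place of 4-nitrophenyl on a carbonyl carbon. Within the data shown here, no measured pair shows a change of this kind, so no direction can be read from the data, and the expected step of a number 1.7 percentage points lower from compound 1 to compound 4 (within the scatter) is placed within the scatter. Compound 4 is therefore estimated at 35%, with a range from 10% to 65%.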

Compound 4, a percentage reported as inhibition, at one concentration (the size of the read-out at that concentration, not a potency): 36.9%
The estimate for compound 4 lay 1.9 percentage points below the measured number; low and high end bracket the measured number.
By their numbers in this assay, from the lowest: compound 3; then compounds 1 and 4 (each within the scatter of the next); then compound 2.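

In this assay, the step of a number 0.2 percentage points higher from compound 1 to compound 4 (within the scatter) gives the first read on the position of the nitro group: on the core of compound 1, 3-nitrophenyl and 4-nitrophenyl on the carbonyl carbon are not told apart at the one concentration tested. This holds for this core and this pair only. Nothing at hand explains the result.

Open, going by these compounds, is whether the same swap leaves the number unchanged on the core of compound 2. Also open, on these data alone, is what an amine or a carboxylic acid gives in place of the nitro group on this core.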